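Adding a Second Trifluoromethyl Group to Compound 1

The source may report more compounds than this note shows. Statements on the series, on what has been measured and on what is new or still open speak of the compounds shown alone.

Three measured compounds share one core and differ only in how trifluoromethyl groups are placed on a six-membered aromatic ring of carbon only. Compound 1 `FC(F)(F)c1ccc(/C=C\c2cc3ccccc3nc2Cl)cc1` carries a single trifluoromethyl group, compound 2 `FC(F)(F)c1cccc(/C=C\c2cc3ccccc3nc2Cl)c1` carries a single one arranged differently, and compound 3 `FC(F)(F)c1cc(/C=C\c2cc3ccccc3nc2Cl)cc(C(F)(F)F)c1` carries two. The difference between the cores of compound 1 and compound 2 is not broken down here. In a functional assay on MDA-MB-231 cells (Homo sapiens) for antiproliferative activity, read by sulforhodamine B assay, with a stated time of 72 h (on this read-out higher numbers stand for weaker inhibition and lower numbers for stronger inhibition), compound 1 gives 5360 nM, compound 2 gives 3750 nM and compound 3 gives 10100 nM. The values of compound 1 and compound 2 lie within the scatter of each other. From compound 2 to compound 3 the change is trifluoromethyl in place of hydrogen on an aromatic carbon, and it brings a 2.7-fold higher number from compound 2 to compound 3 (0.43 log units; beyond the scatter).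

Compound 4 `FC(F)(F)c1ccc(/C=C\c2cc3ccccc3nc2Cl)c(C(F)(F)F)c1` has not yet been measured in this assay. It arises from compound 1 by the same kind of change, (trifluoromethyl in place of hydrogen on an aromatic carbon). The surroundings differ: in compound 4 the entering group sits ortho to a large group, whereas in compound 3 it sits meta to a large group. For the measured compounds named here, the only guide is the step from compound 2 to compound 3 of a 2.7-fold higher number from compound 2 to compound 3 (0.43 log units; beyond the scatter), a modest weakening. Resting on that single step, the estimate is a step of a 2.2-fold higher number from compound 1 to compound 4 (0.35 log units; beyond the scatter), set beside the earlier one in size. Compound 4 is therefore expected to give about 12000 nM in this assay, with a likely range from 5000 nM to 30000 nM.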

Compound 4, half-maximal inhibitory concentration: 41800 nM
Compound 4: middle estimate off by 3.5-fold (0.54 log units), on the low side; the whole stated range lies below it.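

In this assay, the second trifluoromethyl group on the core of compound 1 again weakens inhibition, with a 7.8-fold higher number from compound 1 to compound 4 (0.89 log units; beyond the scatter). The direction of the change therefore holds for both pairs, but its size does not carry over from one to the other, so a step read on one core gives only a loose guide to the other: the same change on two cores in this assay, a 2.7-fold higher number (0.43 log units; beyond the scatter) from compound 2 to compound 3 and a 7.8-fold higher number (0.89 log units; beyond the scatter) from compound 1 to compound 4, 2.9-fold (0.46 log units) apart, beyond the scatter of two such steps

For the compounds shown here, this comparison rests on only two pairs and does not show what sets the two sizes apart: the entering group in compound 4 sits ortho to a large group, but the starting compounds also differ, and the data cannot separate these two differences or say which size a further core would follow.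

The compounds shown leave open whether a methyl group, a methoxy group or an amine entering at the same place as the second trifluoromethyl group of compound 4 would bring a step of similar size. They also leave open how a compound with the shared core and no trifluoromethyl group at all would stand in this assay.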